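Chloro for hydrogen across two related cores

A few compounds are considered here, and "the series" means these few. Any claim that something is new, unique, unknown or untested is made for them only; others in the source may bear on it.

Compound 1 `Cn1cncc1-c1ccccc1O` in an assay on cells for inhibition of Indoleamine 2,3-dioxygenase 1 (Homo sapiens), read by HPLC, with a stated time of 20 min (on this read-out higher numbers stand for weaker inhibition and lower numbers for stronger inhibition), gives 38000 nM.
Compound 2 `Cn1cncc1-c1cc(Cl)ccc1O` in this assay gives 17000 nM.
Compound 3 `Oc1ccccc1-n1ccnc1` in this assay gives 16000 nM.

Compounds 1 and 2 share a core and differ by chloro in place of hydrogen on an aromatic carbon; this change gave a 2.2-fold lower number from compound 1 to compound 2 (0.35 log units; beyond the scatter). Compound 3 carries a different core, and the difference between the two cores is not broken down here. Compound 3 and compound 2 lie within the scatter of each other, while compound 1 sits beyond the scatter from compound 3.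

Compound 4 `Oc1ccc(Cl)cc1-n1ccnc1` is not yet measured. It differs from compound 3 by chloro in place of hydrogen on an aromatic carbon. This is the same kind of change as that from compound 1 to compound 2, though the surroundings differ: in compound 4 the chloro is meta to a group of 5 heavy atoms, whereas in compound 2 it is meta to a group of 6 heavy atoms. In this assay, among the measured compounds shown here, the step from compound 3 to compound 4 is expected to be about a 2.1-fold lower number from compound 3 to compound 4 (0.33 log units; beyond the scatter), resting on the single step of a 2.2-fold lower number from compound 1 to compound 2 (0.35 log units; beyond the scatter) seen on the other core. Compound 4 is therefore estimated at 7500 nM, with a likely range from 3500 nM to 16000 nM.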

Compound 4, half-maximal inhibitory concentration: 2100 nM
For compound 4 the middle estimate is 3.6-fold (0.55 log units) above the measured one; the whole stated range lies above it.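

In this assay, chloro in place of hydrogen on an aromatic carbon, para to a hydroxy group, gives a 7.6-fold lower number from compound 3 to compound 4 (0.88 log units; beyond the scatter), so the direction of the earlier step carries over to the second core. The size does not carry over, and the two steps stand clearly apart: the same change on two cores in this assay, a 2.2-fold lower number (0.35 log units; beyond the scatter) from compound 1 to compound 2 and a 7.6-fold lower number (0.88 log units; beyond the scatter) from compound 3 to compound 4, 3.4-fold (0.53 log units) apart, beyond the scatter of two such steps

With one pair on each core, this shows that the size of the step depends on the core in these compounds, but it does not show which feature of the cores is responsible or how the change would behave on any further core.

Still open, from the compounds shown here alone, is whether the larger step is specific to chloro, or whether a methoxy group, a trifluoromethyl group or an amine at the same place would also give different steps on the two cores. Also open, going by these compounds, is how chloro would act on another carbon of the same ring on either core.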